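Aryl swap on the amine-bound chain carbon: compound 3

The source may hold more compounds than are shown below. What is called first, only, known or untested is meant among the compounds shown, and "the series" means these compounds.

Measured so far:
compound 1 `CNC(=O)c1cnc(N2CCN(C3CCN(Cc4ccco4)CC3)[C@@H](C)C2)c(Cl)c1` — 8100 nM
compound 2 `CNC(=O)c1cnc(N2CCN(C3CCN(Cc4ccccn4)CC3)[C@@H](C)C2)c(Cl)c1` — 7990 nM

In a functional assay for antagonist activity at C-X-C chemokine receptor type 3 (Homo sapiens) (a lower number here means a stronger inhibitor, a higher number a weaker inhibitor), compound 1 gives 8100 nM and compound 2 gives 7990 nM. Within the data shown here, compound 2 holds the lower of the two numbers, but the only step between them, a 1.0-fold lower number from compound 1 to compound 2 (0.01 log units; within the scatter), lies within the scatter, so the two compounds are indistinguishable on these data.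

Compound 3 `CNC(=O)c1cnc(N2CCN(C3CCN(Cc4ccc(C)cc4)CC3)[C@@H](C)C2)c(Cl)c1` continues the same theme: 4-methylphenyl in place of pyridin-2-yl on a saturated chain carbon bound to an amine nitrogen in a ring. Among the measured compounds shown here, the one measured step that bears on this position, a 1.0-fold lower number from compound 1 to compound 2 (0.01 log units; within the scatter), shows that exchanging one aromatic group for another on this chain carbon left this assay unchanged. For the measured compounds named here, only one such step exists, so the expectation rests on a single pair.

Compound 3 is therefore expected to give about 8000 nM in this assay, with a range from 3000 nM to 20000 nM. The estimated step of a 1.0-fold higher number from compound 2 to compound 3 (0.00 log units; within the scatter) is expected to stay within the scatter.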

Compound 3, half-maximal inhibitory concentration: 87 nM
Compound 3: middle estimate off by 92-fold (1.96 log units), on the high side, and the stated range ends above it.
By their numbers in this assay, from the lowest: compound 3; then compounds 2 and 1 (each within the scatter of the next).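

In this assay the saturated chain carbon bound to an amine nitrogen in a ring does respond to the aromatic group it carries: the number falls sharply with 4-methylphenyl against pyridin-2-yl (a 92-fold lower number from compound 2 to compound 3 (1.96 log units; beyond the scatter)) and against furan-2-yl (a 93-fold lower number from compound 1 to compound 3 (1.97 log units; beyond the scatter)). The earlier pair showed only that furan-2-yl and pyridin-2-yl could not be told apart, so exchanges of one aromatic group for another are not neutral as a class. Nothing measured here accounts for the step.

Open, on these data alone, is whether the step belongs to the all-carbon ring itself or to the methyl group of 4-methylphenyl, which phenyl, 4-chlorophenyl or 4-methoxyphenyl at this place would help separate. Also open, as far as these compounds go, is how a longer chain leading to the 4-methylphenyl ring would read in this assay and whether the gain would survive it.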